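Swapping dichlorophenyl for cyanophenyl on a sulfonyl group

The compounds below may be only part of what the source reports. "The series", "measured", "known", "first", "only" and "open" are said of these compounds alone.

Compound 1 `CC1CCN(c2c(S(=O)(=O)c3cccc(F)c3)cnc3ccc(Cl)cc23)CC1`: 58%
Compound 2 `Cc1ccc(S(=O)(=O)c2cnc3ccc(Cl)cc3c2N2CCC(C)CC2)cc1F`: 68%
Compound 3 `CC1CCN(c2c(S(=O)(=O)c3ccc(Cl)c(Cl)c3)cnc3ccc(Cl)cc23)CC1`: 86%

Of the compounds shown here, three sharing one core have been measured in an assay on isolated protein for displacement of a labelled ligand from metabotropic glutamate receptor 5 (Homo sapiens), with a stated time of 60 min, tested at 1 uM; on this read-out lower numbers stand for less inhibition and higher numbers for more inhibition at the one concentration tested (going by the name of the read-out). Compound 3 gives 86% and stands highest of the three; the steps of a number 18 percentage points higher from compound 2 to compound 3 (beyond the scatter) and a number 28 percentage points higher from compound 1 to compound 3 (beyond the scatter) are both beyond the scatter, so its lead over compound 2 and compound 1 is real. The step of a number 10 percentage points higher from compound 1 to compound 2 (within the scatter), by contrast, lies within the scatter.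

Compound 4 `CC1CCN(c2c(S(=O)(=O)c3cccc(C#N)c3)cnc3ccc(Cl)cc23)CC1` carries a single change from compound 3: 3-cyanophenyl in place of 3,4-dichlorophenyl on a sulfonyl sulfur. The two steps that bear on this both moved toward the 3,4-dichlorophenyl group, and both were modest gains. Compound 1, which carries a 3-fluorophenyl group on the same sulfonyl sulfur, gives 58% in this assay, so leaving the dichlorophenyl group has so far meant a lower number. A drop of similar size is therefore expected for compound 4, roughly undoing the gain a number 28 percentage points higher from compound 1 to compound 3 (beyond the scatter). The expected step is a number 34 percentage points lower from compound 3 to compound 4 (beyond the scatter). Compound 4 is estimated at 52%, within a range from 32% to 70%.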

Compound 4, a percentage reported as inhibition, at one concentration (the size of the read-out at that concentration, not a potency): 90%
Beside the measured number, compound 4's estimate is 38 percentage points below it, and the stated range ends below it.
By their numbers in this assay, from the lowest: compounds 1 and 2 (each within the scatter of the next); then compounds 3 and 4 (each within the scatter of the next).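

On the sulfonyl sulfur, the 3,4-dichlorophenyl group turns out not to be required in this assay: the step of a number 4 percentage points higher from compound 3 to compound 4 (within the scatter) shows that 3-cyanophenyl, which carries no chlorine, gives a matching result, so compound 4 goes against the earlier hint that leaving dichlorophenyl lowers the number. The other two steps show how much this aromatic group matters, with a number 22 percentage points higher from compound 2 to compound 4 (beyond the scatter) and, for cyano in place of fluoro on a single aromatic carbon, a number 32 percentage points higher from compound 1 to compound 4 (beyond the scatter). Nothing measured here explains these differences.

On these data alone, it remains open whether an amide, a carboxylic acid or an amine in place of the cyano would hold the number at this level. A single tested concentration also leaves open whether compound 3 and compound 4 would match in potency.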